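Cytotoxicity of a triazole thioacetamide on changing the amide substituent

This account rests on a few compounds, and the source may have more. Where it says the series, first, only, none or still open, it means among the compounds named here.

Measured in an ADME assay on MT4 cells (Homo sapiens) for cytotoxicity, read by MTT assay, with a stated time of 5 days; a lower number here means that less compound is tolerated, a higher number that more compound is tolerated:
- compound 1 `O=C(CSc1ncnn1-c1ccc(Cl)cc1Cl)Nc1cccnc1Cl`: 98500 nM
- compound 2 `CC(=O)c1ccc(NC(=O)CSc2ncnn2-c2ccc(Cl)cc2Cl)c(Br)c1`: 114000 nM

These two numbers lie within the usual scatter of each other, so compound 1 stands level with compound 2. Compound 3 `O=C(CSc1ncnn1-c1ccc(Cl)cc1Cl)Nc1ccc(Cl)cc1Br`, still unmeasured, carries 2-bromo-4-chlorophenyl in place of 2-chloropyridin-3-yl on an amide-type nitrogen. Among the measured compounds shown here, no measured pair shows a step of this kind, so the expectation is uncertain. In this assay, no change beyond the scatter is expected, and any small move would more likely be towards a lower number. The expected step is a 1.4-fold lower number from compound 1 to compound 3 (0.15 log units; within the scatter). For compound 3 the estimated value is 70000 nM, with an expected range from 22000 nM to 160000 nM.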

Compound 3, half-maximal cytotoxic concentration: 189000 nM
Beside the measured number, compound 3's estimate is 2.7-fold (0.43 log units) below it; the measured number lies above the stated range.
By their numbers in this assay, from the lowest: compounds 1, 2 and 3 (each within the scatter of the next).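

In this assay the amide-type nitrogen carries 2-bromo-4-chlorophenyl, a ring of carbon only, in place of 2-chloropyridin-3-yl (a 1.9-fold higher number from compound 1 to compound 3 (0.28 log units; within the scatter)), so the hetero atom of that ring is not needed for the number to stay within the scatter. Chloro in place of acetyl on an aromatic carbon likewise stays within it (a 1.7-fold higher number from compound 2 to compound 3 (0.22 log units; within the scatter)). No measurement bears on the cause of these results. Still open, on these data alone, is whether an amine or a carboxylic acid on that aromatic carbon, or a longer chain on the amide-type nitrogen, would give a step beyond the scatter.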